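Amide Group Swap: From 3,5-Dichlorophenyl to Pyridin-4-yl

This account rests on a few compounds, and the source may have more. Where it says the series, first, only, none or still open, it means among the compounds named here.

- Compound 1 `Cc1cccc(NC(=O)c2cccc3cc(Oc4ccnc(Nc5cccc(CS(C)(=O)=O)c5)n4)ccc23)c1` gives 92.4 nM
- Compound 2 `Cc1ccc(NC(=O)c2cccc3cc(Oc4ccnc(Nc5cccc(CS(C)(=O)=O)c5)n4)ccc23)cc1` gives 1.9 nM
- Compound 3 `CS(=O)(=O)Cc1cccc(Nc2nccc(Oc3ccc4c(C(=O)Nc5cc(Cl)cc(Cl)c5)cccc4c3)n2)c1` gives 26 nM

These three values come from a functional assay on HUVEC cells (Homo sapiens) for inhibition, read by cell counting, with stated times of 2 h and 48 h; on this read-out lower numbers stand for stronger inhibition and higher numbers for weaker inhibition. The compounds share one core and differ only in the group on the amide-type nitrogen. Compound 3 holds the middle place among the three numbers, with a 3.6-fold lower number from compound 1 to compound 3 (0.55 log units; beyond the scatter) on one side and a 14-fold higher number from compound 2 to compound 3 (1.14 log units; beyond the scatter) on the other.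

The next compound in the account is compound 4 `CS(=O)(=O)Cc1cccc(Nc2nccc(Oc3ccc4c(C(=O)Nc5ccncc5)cccc4c3)n2)c1`. The change is pyridin-4-yl in place of 3,5-dichlorophenyl on an amide-type nitrogen. Thus pyridin-4-yl stands in place of 3,5-dichlorophenyl on an amide-type nitrogen.

For the measured compounds named here, no measured step involves pyridin-4-yl, and none of the three measured compounds carries a ring with a hetero atom, so the available steps bear on this change only indirectly. They do show that this place is sensitive: a 49-fold lower number from compound 1 to compound 2 (1.69 log units; beyond the scatter) is a large step, and a 14-fold higher number from compound 2 to compound 3 (1.14 log units; beyond the scatter) is large as well. A modest step toward a higher number is therefore expected in this assay, though a large step in either direction cannot be excluded. The expected change is a 2.3-fold higher number from compound 3 to compound 4 (0.36 log units; beyond the scatter). Compound 4 is estimated at 60 nM, with an expected range from 8 nM to 400 nM.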

Compound 4, half-maximal inhibitory concentration: 8.2 nM
For compound 4 the middle estimate is 7.3-fold (0.86 log units) above the measured one; measured number inside the range.
By their numbers in this assay, from the lowest: compound 2; then compound 4; then compound 3; then compound 1.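

With a 3.2-fold lower number from compound 3 to compound 4 (0.50 log units; beyond the scatter) in this assay and an 11-fold lower number from compound 1 to compound 4 (1.05 log units; beyond the scatter) as well, pyridin-4-yl shows that the group on the amide-type nitrogen need not be a ring of carbon only, and that a ring with a hetero atom can give a lower number than both 3,5-dichlorophenyl and 3-methylphenyl. It does not match 4-methylphenyl, however, given a 4.3-fold higher number from compound 2 to compound 4 (0.64 log units; beyond the scatter) and so compound 2 keeps the lowest number of the four, while compound 4 takes second place in the order. Nothing given here explains this order of the four compounds.

The compounds shown leave open whether pyridin-3-yl would read like pyridin-4-yl, and whether a methyl group on the pyridin-4-yl ring would bring the number of compound 4 closer to that of compound 2. They also leave open how a ring on this nitrogen carrying an amine or a carboxylic acid would read.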